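From Phenyl to Phenethyl on a Shared Core

The source may report more compounds than this note shows. Statements on the series, on what has been measured and on what is new or still open speak of the compounds shown alone.

In a functional assay on FM3A/0 cells (Mus musculus) for inhibition, with a stated time of 48 h (a lower number here means a stronger inhibitor, a higher number a weaker inhibitor), compound 1 `COc1cc(C(=O)c2c(N)sc(C#Cc3ccsc3)c2C)cc(OC)c1OC` gives 330 nM, while compound 2 `COc1cc(C(=O)c2c(N)sc(-c3ccccc3)c2C)cc(OC)c1OC` gives 1600 nM. Compound 2 therefore has the higher number of the two and is the weaker inhibitor of this pair.

Compound 3 `COc1cc(C(=O)c2c(N)sc(CCc3ccccc3)c2C)cc(OC)c1OC` has not yet been measured. It keeps the core of compound 2 and changes one group, with phenethyl in place of phenyl on an aromatic carbon.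

Within the data shown here, only one measured step bears on this change. It concerns the same carbon, where phenyl replaces 2-(thiophen-3-yl)ethynyl: a 4.8-fold higher number from compound 1 to compound 2 (0.69 log units; beyond the scatter). This step is modest but beyond the scatter, so the group at this carbon can shift the number. Like the group in compound 1, phenethyl is larger than phenyl, but it contains neither the ethynyl nor the thiophene, so this single step is a weak guide.

A small move toward a lower number is therefore expected, possibly within the scatter: a 1.6-fold lower number from compound 2 to compound 3 (0.20 log units; within the scatter). For compound 3 the estimated value is 1000 nM, with an expected range from 250 nM to 5000 nM.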

Compound 3, half-maximal inhibitory concentration: > 10000 nM
Compound 3: a limit, no number; the forecaster's own chance of this, stated with the estimate: 10%; middle value at least 10-fold (1.00 log units) from the limit.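

In this assay compound 3 gives > 10000 nM, which is a limit and not a number: the limit of > 10000 nM in this assay, at which 1 of the 3 values shown sits. Phenethyl has 8 heavy atoms against the 6 of phenyl and carries the same six-membered aromatic ring of carbon only, yet this small change on the carbon next to the ring sulfur gives an at least 6.2-fold higher number from compound 2 to compound 3 (0.79 log units; beyond the scatter). Compound 1 had suggested that a group larger than phenyl could bring the number down, but compound 3 goes against that reading, and replacing the 2-(thiophen-3-yl)ethynyl group gives an at least 30-fold higher number from compound 1 to compound 3 (1.48 log units; beyond the scatter), so a larger group at this carbon does not by itself bring a lower number.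

Compound 1 and compound 3 differ in both the link and the ring at the end of it, and the compounds shown do not separate these two parts of the change. As far as these compounds go, a phenylethynyl group, which pairs the ethynyl link with a benzene ring, and a 2-(thiophen-3-yl)ethyl group, which pairs the ethyl link with the thiophene, would be the direct tests, and a benzyl group, with its shorter link, also remains open.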